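A Carbonyl Group Replaces 3-Chlorophenyl in Compound 1

The compounds below may be only part of what the source reports. "The series", "measured", "known", "first", "only" and "open" are said of these compounds alone.

Compound 1 `O=C(NNc1cccc(Cl)c1)c1ccc(NS(=O)(=O)c2cnc(O)nc2O)cc1`: 11600 nM
Compound 2 `O=C(NNc1ccccc1F)c1ccccc1NS(=O)(=O)c1cnc(O)nc1O`: > 20000 nM

For the measured compounds named here, in a functional assay on SGC-7901 cells (Homo sapiens) for antiproliferative activity, read by MTT assay, with a stated time of 24 h (a lower number here means a stronger inhibitor, a higher number a weaker inhibitor), compound 1 gives 11600 nM, the only true number available so far. Compound 2 gives > 20000 nM, which is a limit of the assay and not a number.

Compound 3 `Cc1ccc(C(=O)NNC(=O)c2ccc(NS(=O)(=O)c3cnc(O)nc3O)cc2)cc1` keeps the core of compound 1 but carries (4-methylphenyl)carbonyl in place of 3-chlorophenyl on an amine nitrogen. Going by the values given here, no two measured compounds differ in only one place, so the effect of a change like this has not been observed directly. Nothing beyond the usual scatter is therefore expected, and the estimated 1.2-fold higher number from compound 1 to compound 3 (0.08 log units; within the scatter) leans only slightly toward a weaker inhibitor. Compound 3 is expected to give about 14000 nM, with an estimated range of 6000 nM to 32000 nM.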

Compound 3, half-maximal inhibitory concentration: > 20000 nM
Compound 3 ended at the assay's limit; the forecaster's own chance of this, stated with the estimate: 35%; middle value at least 1.4-fold (0.15 log units) from the limit.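

In this assay, compound 3 sits at a limit of the assay and not at a number, so only a floor on this change can be read. Putting (4-methylphenyl)carbonyl in place of 3-chlorophenyl on this amine nitrogen gives an at least 1.7-fold higher number from compound 1 to compound 3 (0.23 log units; that floor lies within the scatter), so this first direct look at the position shows no gain, and the loss could be small or far larger. The true size stays hidden because the measurable range ends not far from the value of compound 1: the limit of > 20000 nM in this assay, at which 2 of the 3 values shown sit.

As far as these compounds go, the change brings in the carbonyl and the 4-methyl together, so the effect of each alone remains unknown. Also open, from the compounds shown here alone, is whether a plain benzoyl, an acetyl or a methyl group on this amine nitrogen would give a lower number.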